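The source may hold more compounds than are shown below. What is called first, only, known or untested is meant among the compounds shown, and "the series" means these compounds.

Measured so far in a functional assay on B16-F10 cells (Mus musculus) for inhibition, read by colorimetric assay and MTT assay, with a stated time of 72 h; on this read-out lower numbers stand for stronger inhibition and higher numbers for weaker inhibition:
compound 1, `Cc1ccc(C(=O)NNC(=S)Nc2csc(-c3ccccc3)c2)cc1`, gives 24000 nM
compound 2, `Cc1ccc(C(=O)NNC(=S)Nc2csc(-c3ccc(C)cc3)c2)cc1`, gives 20000 nM
compound 3, `COc1cc(C(=O)NNC(=S)Nc2csc(-c3ccccc3)c2)cc(OC)c1OC`, gives 32000 nM

Compound 3 carries the highest of the three numbers, but its gaps to compound 1 and to compound 2 both lie within the scatter, so no ranking among the three can be read from these values. Compound 4, `COc1cc(C(=O)NNC(=S)Nc2csc(-c3ccc(C)cc3)c2)cc(OC)c1OC`, is not yet measured in this assay. It differs from compound 3 by methyl in place of hydrogen on an aromatic carbon. Among the compounds with values here, one measured step bears directly on this change, the same methyl for hydrogen on the same place, a 1.2-fold lower number from compound 1 to compound 2 (0.08 log units; within the scatter), which stays within the scatter. On that single precedent the change in this assay is expected to be small, with no direction beyond the scatter. The expected step is a 1.2-fold lower number from compound 3 to compound 4 (0.07 log units; within the scatter). Compound 4 is therefore estimated at about 27000 nM in this assay, with a range from 14000 nM to 55000 nM. Because only a 1.2-fold lower number from compound 1 to compound 2 (0.08 log units; within the scatter) supports the estimate, the range is kept wide.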

Compound 4, half-maximal inhibitory concentration: 13000 nM
For compound 4 the middle estimate is 2.1-fold (0.32 log units) above the measured one, outside the stated range (below it).
By their numbers in this assay, from the lowest: compounds 4, 2, 1 and 3 (each within the scatter of the next, the first and the last beyond it).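

In this assay, within the data shown here, the change from phenyl to 4-methylphenyl now gives a step beyond the scatter, a 2.5-fold lower number from compound 3 to compound 4 (0.39 log units; beyond the scatter), whereas the only earlier example of this change stayed within it. This step is modest, so the methyl at this place can lower the number on at least one core, but only to a limited extent. No dependence on the core can be claimed, as the two steps do not differ beyond what their scatter allows: the same change on two cores in this assay, a 1.2-fold lower number (0.08 log units; within the scatter) from compound 1 to compound 2 and a 2.5-fold lower number (0.39 log units; beyond the scatter) from compound 3 to compound 4, 2.1-fold (0.31 log units) apart, within the scatter of two such steps

The compounds shown leave open whether another group on this aromatic carbon, such as a chlorine, a methoxy group or an amine, would move the number further or in the opposite direction. They also leave open whether a methyl elsewhere on this six-membered ring would give a step of similar size.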